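Benzoyl replaced by benzyl: compound 2 to compound 3

A few compounds are considered here, and "the series" means these few. Any claim that something is new, unique, unknown or untested is made for them only; others in the source may bear on it.

Among the measured compounds shown here, in an assay on nucleic acid for inhibition of Nucleic Acid, read by fluorescence, tested at 100 uM (a lower number here means less inhibition, a higher number more inhibition at the concentration tested (going by the name of the read-out)), compound 2 `CCOC(=O)C1CCCN(Cc2cn(CC(O)COC(=O)c3ccccc3)nn2)C1` gives 6%, the lower of the two numbers measured so far; compound 1 `OC1CCCCC1n1cc(CN2CCN(c3ccccc3)CC2)nn1` gives 47%, a gap well beyond the scatter. Compound 3 `CCOC(=O)C1CCCN(Cc2cn(CC(O)COCc3ccccc3)nn2)C1` has not been measured. It differs from compound 2 in one place: benzyl in place of benzoyl on an oxygen on a saturated carbon. For the measured compounds named here, no step between measured compounds covers this change, so the expectation rests on compound 2 alone, which gives 6%. The step of a number 4 percentage points higher from compound 2 to compound 3 (within the scatter) is expected to stay within the scatter, with no clear direction. Compound 3 is therefore estimated at 10%, in a range from 0% to 30%.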

Compound 3, a percentage reported as inhibition, at one concentration (the size of the read-out at that concentration, not a potency): 26%
Compound 3: middle estimate off by 16 percentage points, on the low side; the measured number falls inside the stated range.
By their numbers in this assay, from the lowest: compound 2; then compound 3; then compound 1.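

In this assay, this position responds to the group on the oxygen: benzyl in place of benzoyl gives a number 20 percentage points higher from compound 2 to compound 3 (beyond the scatter). The six-membered aromatic ring is common to both groups, so what leaves is the carbonyl, with its double bond and one hydrogen-bond acceptor. No available evidence explains why the number moves.

Still open, as far as these compounds go, is whether phenethyl, a longer chain on this oxygen, extends the rise, and whether a free hydroxyl there brings the number back down.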